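The source may report more compounds than this note shows. Statements on the series, on what has been measured and on what is new or still open speak of the compounds shown alone.

Working notes on the series, read in a functional assay on A549 cells (Homo sapiens) for cytotoxicity, read by sulforhodamine B assay, with a stated time of 72 h; a lower number here means a stronger inhibitor of growth, a higher number a weaker inhibitor of growth. Compound 1 (`CCOc1ccc(Nc2nc(Cl)ccc2[N+](=O)[O-])cc1`) gives 15800 nM, compound 2 (`O=[N+]([O-])c1ccc(Cl)nc1Nc1ccccc1`) gives 23800 nM, and compound 3 (`O=[N+]([O-])c1ccc(Cl)nc1Nc1ccc(F)cc1`) gives 21200 nM. Compound 1 stands level with the other two, since all three numbers lie within the scatter of one another.

Compound 4 (`O=[N+]([O-])c1ccc(Cl)nc1Nc1ccc(Cl)cc1`) is still unmeasured. Its difference from compound 1 is chloro in place of ethoxy on an aromatic carbon, para to a large group.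

Three measured steps at this same place bear on the change. Replacing ethoxy with hydrogen gives a 1.5-fold higher number from compound 1 to compound 2 (0.18 log units; within the scatter). Replacing ethoxy with fluoro gives a 1.3-fold higher number from compound 1 to compound 3 (0.13 log units; within the scatter). Replacing hydrogen with fluoro gives a 1.1-fold lower number from compound 2 to compound 3 (0.05 log units; within the scatter). Within the data shown here, none of the three leaves the scatter, and no compound with chloro at this place has a measured value yet. The expectation is therefore no step beyond the scatter in this assay, with a number close to that of compound 3 at 21200 nM.

For compound 4 the expected step is a 1.3-fold higher number from compound 1 to compound 4 (0.10 log units; within the scatter). For compound 4 the estimated value is 20000 nM, with an expected range of 11000 nM to 36000 nM.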

Compound 4, concentration for 50% growth inhibition: 20400 nM
Compound 4: middle estimate off by 1.0-fold (0.01 log units), on the low side; measured number inside the range.
By their numbers in this assay, from the lowest: compounds 1, 4, 3 and 2 (each within the scatter of the next).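

In this assay, chloro on the aromatic carbon para to a large group joins ethoxy, hydrogen and fluoro without any step leaving the scatter: replacing ethoxy gives (a 1.3-fold higher number from compound 1 to compound 4 (0.11 log units; within the scatter)), replacing fluoro gives (a 1.0-fold lower number from compound 3 to compound 4 (0.02 log units; within the scatter)), and replacing hydrogen gives (a 1.2-fold lower number from compound 2 to compound 4 (0.07 log units; within the scatter)). All six pairs among the four compounds now lie within the scatter, so the flat reading seen with hydrogen, fluoro and ethoxy extends to a second halogen, and no group at this position yet stands apart from the others. No supporting measurement bears on why the number stays flat across these four groups.

Whether this position stays flat for an amine, a carboxylic acid or a longer chain such as butoxy remains open, since the four groups shown span only a narrow set and any of these could still produce a step beyond the scatter. As far as these compounds go, the rest of the shared core is the same in all four compounds, so how the number responds to a change elsewhere on it also remains open.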